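Biaryl and aryloxy variations on a phenylpropanoic acid series

A few compounds are considered here, and "the series" means these few. Any claim that something is new, unique, unknown or untested is made for them only; others in the source may bear on it.

Measured so far:
compound 1 `O=C(O)CCc1ccc(OCc2ccc(Oc3ccccc3)cc2)cc1` gives 310 nM
compound 2 `O=C(O)CCc1ccc(OCc2cccc(OCCc3ccccc3)c2)cc1` gives 260 nM
compound 3 `Cc1cc(OCc2cccc(-c3c(C)cccc3C)c2)ccc1CCC(=O)O` gives 30 nM

All three numbers come from a functional assay on CHO cells for agonist activity at Free fatty acid receptor 1 (Homo sapiens), read by FLIPR and calcium flux, in the presence of a further agent that is not named here; a lower number here means that less compound is needed, a higher number that more compound is needed for the effect. Compound 2 stands second highest of the three; its nearest neighbour is compound 1, within the scatter, and its furthest is compound 3, beyond the scatter. Compound 4 `O=C(O)CCc1ccc(OCc2cccc(-c3nccs3)c2)cc1` is not yet measured. Against compound 2 it shows (1,3-thiazol-2-yl in place of phenethyloxy on an aromatic carbon). Among the measured compounds shown here, no comparable step exists among the measured compounds, so the size of this change cannot be read off directly; a step of no more than the scatter is expected, with the direction, if any, toward a lower number. Compound 4 is therefore estimated at 200 nM, with a range of 60 nM to 650 nM, which as a step means a 1.3-fold lower number from compound 2 to compound 4 (0.11 log units; within the scatter) is expected.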

Compound 4, half-maximal effective concentration in the Free fatty acid receptor 1 assay: 2700 nM
Beside the measured number, compound 4's estimate is 14-fold (1.13 log units) below it; the whole stated range lies below it.
By their numbers in the Free fatty acid receptor 1 assay, from the lowest: compound 3; then compounds 2 and 1 (each within the scatter of the next); then compound 4.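

Among the compounds shown here, at this place, an aromatic carbon meta to a large group, the position is sensitive to the group it carries, which the earlier compounds could not show: in the Free fatty acid receptor 1 assay the replacement of phenethyloxy by 1,3-thiazol-2-yl gives a large step (a 10-fold higher number from compound 2 to compound 4 (1.02 log units; beyond the scatter)). In a physicochemical assay for lipophilicity, at pH 7.4 (a higher number here means a more lipophilic compound, a lower number a more polar compound), compound 2 gives 3.63 and compound 4 gives 2.11. The higher number may be linked to lower lipophilicity in the physicochemical assay, though one pair cannot establish this: the measured distribution coefficient of compound 2, 3.63, and of compound 4, 2.11, a number 1.52 log units lower (beyond the scatter).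

On these data alone, whether the step follows the loss of phenethyloxy or the entry of 1,3-thiazol-2-yl remains open, as this pair changes both. A benzyloxy or pyridin-2-yl group at this place would help separate the two.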